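A few compounds are considered here, and "the series" means these few. Any claim that something is new, unique, unknown or untested is made for them only; others in the source may bear on it.

Measured so far:

compound 1, `COc1ccc(-c2cc(/C=C/C(=O)c3ccc(N)cc3)[nH]n2)cc1`: 36100 nM
compound 2, `COc1cc(-c2cc(/C=C/C(=O)c3ccc(N)cc3)[nH]n2)cc(OC)c1OC`: 8170 nM

Both compounds share the same core and differ only in the methoxy groups on one aromatic ring. In a functional assay on M14 cells (Homo sapiens) for inhibition, read by sulforhodamine B assay, with a stated time of 48 h (a lower number here means that less compound is tolerated, a higher number that more compound is tolerated), compound 1 gives 36100 nM, whereas compound 2 gives 8170 nM. Of these two numbers, that of compound 2 is the lowest, so compound 2 is the one of which the cells tolerate the least; its gap to compound 1 lies beyond the usual scatter of this assay.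

Compound 3, `COc1ccc(-c2cc(/C=C/C(=O)c3ccc(N)cc3)[nH]n2)cc1OC`, has not yet been measured in this assay. Compared with compound 2 it carries hydrogen in place of methoxy on an aromatic carbon, in words: hydrogen in place of methoxy on an aromatic carbon. Among the measured compounds shown here, no pair of measured compounds shows exactly this exchange, so the size of the step cannot be read from a measured pair. Compound 3 keeps two of the three methoxy groups of compound 2 and thus lies structurally between compound 2 and compound 1. The number for compound 3 is therefore expected to rise toward that of compound 1, by a step beyond the scatter. For compound 3 the estimate is 16000 nM, with a range from 5000 nM to 45000 nM. The expected step is a 2.0-fold higher number from compound 2 to compound 3 (0.29 log units; within the scatter).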

Compound 3, concentration lethal to 50% of the cells: 15000 nM
Compound 3: the middle estimate sits 1.1-fold (0.03 log units) above what was measured, within the range that was stated.
By their numbers in this assay, from the lowest: compounds 2 and 3 (each within the scatter of the next); then compound 1.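

In this assay, the exchange of methoxy for hydrogen can now be read from single-place pairs, and the two steps differ in what they show. Taking away the methoxy group that sits ortho to a methoxy group and meta to a large group gives a 1.8-fold higher number from compound 2 to compound 3 (0.26 log units; within the scatter), so at this position the compounds cannot be told apart, and this methoxy group shows no clear contribution to the reading. Adding a methoxy group to an aromatic carbon of compound 1 gives a 2.4-fold lower number from compound 1 to compound 3 (0.38 log units; beyond the scatter), a modest step but a real one, so the exchange of hydrogen for methoxy does register in this series at that place, and the number moves toward lower values there. Nothing measured here explains why the two places differ in this way.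

What the compounds shown leave open is whether the position in the step from compound 2 to compound 3 is indifferent to any group or only to the exchange of methoxy and hydrogen. A hydroxyl group or a chlorine atom on that aromatic carbon would test this, and a longer chain such as ethoxy would show whether anything larger than methoxy is accepted there.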